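The source may report more compounds than this note shows. Statements on the series, on what has been measured and on what is new or still open speak of the compounds shown alone.

Compound 1 `CCc1ccc(NC(=O)Nc2cc(C)nc3ccccc23)cc1` is a urea joining the shared core to a phenyl ring bearing an ethyl group. In an ADME assay on Raji cells (Homo sapiens) for cytotoxicity, with a stated time of 72 h (on this read-out higher numbers stand for an effect only at larger amounts of compound and lower numbers for an effect already at smaller amounts), compound 1 gives only a limit, > 25000 nM, not a number. Compound 2 `COc1ccc(NC(=O)Nc2cc(C)nc3ccccc23)cc1OC` likewise reaches only the limit > 25000 nM in this assay. Compound 3 `Cc1cc(NC(=O)Nc2ccc(F)c(F)c2)c2ccccc2n1` also stops at the limit > 25000 nM in this assay. So compound 1 stands where every measured compound stands, since the limit of > 25000 nM in this assay, at which 3 of the 3 values shown sit, describes all three. Compound 4 `Cc1cc(NC(=O)Nc2ccc(SC(F)(F)F)cc2)c2ccccc2n1` is not yet measured; it differs from compound 1 by (trifluoromethyl)sulfanyl in place of ethyl on an aromatic carbon. Among the compounds with values here, with no measured step to lean on, the step that the limit leaves unreadable from compound 1 to compound 4 is expected to be none beyond the scatter. For compound 4 the estimate in this assay is 40000 nM, within a range from 15000 nM to 150000 nM, most likely again reported only as a limit.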

Compound 4, half-maximal effective concentration: 10000 nM
Beside the measured number, compound 4's estimate is 4.0-fold (0.60 log units) above it; the whole stated range lies above it.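

At this aromatic carbon, the change to (trifluoromethyl)sulfanyl gives the first readable effect in the series, an at least 2.5-fold lower number from compound 1 to compound 4 (0.39 log units; beyond the scatter) in this assay. That size is only a minimum, as the starting point is a limit and not a number. Compound 4 is the only one of the four compounds with a measured number, and the others remain at the limit: the limit of > 25000 nM in this assay, at which 3 of the 4 values shown sit.

On these data alone, it remains open whether the sulfur or the fluorines matter more. A methylsulfanyl group, a trifluoromethyl group or an amine at this position could separate the two, and the single step shown cannot settle it.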